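Swapping the Aromatic Ring on a Shared Imidazoline Core

This account rests on a few compounds, and the source may have more. Where it says the series, first, only, none or still open, it means among the compounds named here.

Of the compounds shown here, three built on one shared core have been measured in a functional assay with Alpha-1A adrenergic receptor (Homo sapiens) as the target, read by calcium flux; a lower number here means a smaller maximal response, a higher number a larger maximal response. Compound 1, `c1cncc(-c2ccccc2OCC2=NCCN2)c1`, gives 109% in this assay. Compound 2, `c1csc(-c2ccccc2OCC2=NCCN2)c1`, gives 101%, and compound 3, `Cc1csc(-c2ccccc2OCC2=NCCN2)n1`, gives 104%. Compound 1 carries the largest of these three numbers, but the gaps to the others are small: a number 5 percentage points lower from compound 1 to compound 3 (within the scatter) and a number 8 percentage points lower from compound 1 to compound 2 (within the scatter), so all three sit within the usual scatter of one another. The same holds for a number 3 percentage points higher from compound 2 to compound 3 (within the scatter).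

The next compound, compound 4, is `Cc1cnsc1-c1ccccc1OCC1=NCCN1`. It differs from compound 1 in one place: 4-methyl-1,2-thiazol-5-yl in place of pyridin-3-yl on an aromatic carbon. Within the data shown here, every measured step so far exchanges the same ring on the same carbon for another small aromatic ring, and none of these steps moved the maximal response beyond the scatter. The change to compound 4 is of the same kind, a five-membered ring with two hetero atoms in place of the six-membered pyridin-3-yl, so a step of about a number 5 percentage points lower from compound 1 to compound 4 (within the scatter) is expected in this assay, that is, no real change in either direction. Compound 4 is therefore estimated to give 104%, with a range from 90% to 118%.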

Compound 4, largest response reached (reported as maximum), in percent of the reference or control that the assay uses: 104%
Compound 4: middle estimate and measured number agree at the digits printed; low and high end bracket the measured number.
By their numbers in this assay, from the lowest: compounds 2, 3, 4 and 1 (each within the scatter of the next).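

With the 4-methyl-1,2-thiazol-5-yl ring on this aromatic carbon, ortho to a group of 7 heavy atoms, the piece now has a third five-membered ring in the place of pyridin-3-yl, and in this assay the readings are a number 5 percentage points lower from compound 1 to compound 4 (within the scatter) and, against the thiophene, a number 3 percentage points higher from compound 2 to compound 4 (within the scatter). The comparison with the other methyl-bearing ring is the new piece of information: 4-methyl-1,2-thiazol-5-yl and 4-methyl-1,3-thiazol-2-yl differ in how the ring is built and joined, yet the reading is no change at the digits printed from compound 3 to compound 4 (within the scatter), so for these four compounds that difference does not register in the maximal response. Nothing available explains why the maximal response holds across these rings.

From the compounds shown here alone, all four groups at this position are small aromatic rings, so it remains open whether the maximal response would hold with a quite different group there, such as a primary amine, a carboxylic acid or a longer alkyl chain. A maximal response also says nothing about how much of each compound is needed to reach it, so these compounds may or may not differ in that respect.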